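Chain extension of the sulfamide arm in compound 1

The source may report more compounds than this note shows. Statements on the series, on what has been measured and on what is new or still open speak of the compounds shown alone.

Compound 1 `NS(=O)(=O)NCC1CCN(c2cc(-c3ccccc3)ncn2)CC1` carries an unsubstituted phenyl on the shared core and the shortest sulfamide arm of the set. In a functional assay on HT-29 cells (Homo sapiens) for antiproliferative activity, read by sulforhodamine B assay, with a stated time of 48 h (on this read-out higher numbers stand for weaker inhibition of growth and lower numbers for stronger inhibition of growth), compound 1 gives only a limit, > 100000 nM, so its own position is known just as a floor on the number. The two measured neighbours change the aromatic ring, not the arm: compound 2 `CCCCc1ccc(-c2cc(N3CCC(CNS(N)(=O)=O)CC3)ncn2)cc1` gives 15200 nM and compound 3 `COC(=O)c1ccc(-c2cc(N3CCC(CNS(N)(=O)=O)CC3)ncn2)cc1` gives 22900 nM. The steps read an at least 6.5-fold lower number from compound 1 to compound 2 (0.81 log units; beyond the scatter), an at least 4.3-fold lower number from compound 1 to compound 3 (0.64 log units; beyond the scatter) and a 1.5-fold higher number from compound 2 to compound 3 (0.18 log units; within the scatter); the first two are bounded on one side because compound 1 sits at the limit of > 100000 nM in this assay, at which 1 of the 3 values shown sits.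

Compound 4 `NS(=O)(=O)NCCC1CCN(c2cc(-c3ccccc3)ncn2)CC1` differs from compound 1 by (sulfamoylamino)methyl in place of sulfamoylamino on a saturated chain carbon bound to a saturated ring carbon. Among the compounds with values here, none of the measured steps touches this part of the molecule, so nothing speaks to the effect of lengthening the arm by one carbon; the only anchor is that compound 1 lies beyond the limit of this assay. The expectation is therefore no step beyond the scatter, a step that the limit leaves unreadable from compound 1 to compound 4, with compound 4 most likely returning a limit as well. Compound 4 is estimated at 150000 nM, within a range of 50000 nM to 500000 nM.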

Compound 4, concentration for 50% growth inhibition: 66500 nM
Compound 4: middle estimate off by 2.3-fold (0.35 log units), on the high side; measured number inside the range.
By their numbers in this assay, from the lowest: compounds 2 and 3 (each within the scatter of the next); then compound 4. At a limit, above all of these: compound 1.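

Of the changes shown, this is the only one on the sulfamide arm rather than the aromatic ring, and with the unsubstituted phenyl kept, compound 4 gives a number rather than a limit in this assay. The step reads an at least 1.5-fold lower number from compound 1 to compound 4 (0.17 log units; that floor lies within the scatter), so placing (sulfamoylamino)methyl in place of sulfamoylamino on a saturated chain carbon bound to a saturated ring carbon cannot yet be called a gain, although the measured value of compound 4 gives the arm change a fixed reference for later comparisons. The true size of this step stays unreadable because compound 1 is itself a limit: the limit of > 100000 nM in this assay, at which 1 of the 4 values shown sits.

Open, on these data alone, is whether the longer arm would keep, add to or lose the lower numbers seen with butyl or methoxycarbonyl on the aromatic ring, a question that needs the arm change and a ring group together in one compound. Also open, as far as these compounds go, is how the read-out responds to a still longer chain in the arm, or to an amine or a carboxylic acid at the end of the arm in place of the sulfamide.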